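The source may report more compounds than this note shows. Statements on the series, on what has been measured and on what is new or still open speak of the compounds shown alone.

Compound 2 `CCCc1nnc(SCc2ccccc2Cl)n1N1C(=O)c2ccccc2C1=O` is known in a functional assay on HepG2 cells (Homo sapiens) for cytotoxicity, read by MTT assay, with a stated time of 48 h (a higher number here means a weaker inhibitor, a lower number a stronger inhibitor), only as a limit, > 200000 nM. Compound 1 `Cc1nnc(SCC(=O)c2ccccc2)n1N1C(=O)c2ccccc2C1=O` likewise gives only a limit in this assay, > 200000 nM. Both values sit at the limit of > 200000 nM in this assay, at which 2 of the 2 values shown sit. Compound 3 `CCCc1nnc(SCC(=O)c2ccccc2)n1N1C(=O)c2ccccc2C1=O` differs from compound 2 by benzoyl in place of 2-chlorophenyl on a saturated chain carbon bound to a sulfur. The step that the limit leaves unreadable from compound 2 to compound 3 expected in this assay is none beyond the scatter, because compound 1 with the same benzoylmethyl group gives > 200000 nM. Compound 3 is therefore expected to give about 300000 nM, with a range from 150000 nM to 600000 nM, most likely reported once more as a limit rather than a number.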

Compound 3, half-maximal inhibitory concentration: > 200000 nM
Compound 3: only a limit was reported; the forecaster's own chance of this, stated with the estimate: 85%; the middle value lies beyond the limit too.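

In this assay compound 3 gives only a limit, > 200000 nM, and its steps from compound 1 and compound 2 cannot be read. The compounds shown leave open which change to the shared core, if any, would give a measurable value in this assay: the limit of > 200000 nM in this assay, at which 3 of the 3 values shown sit.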